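Trimethoxyphenyl replacement on the aryl-imidazolone series

This account rests on a few compounds, and the source may have more. Where it says the series, first, only, none or still open, it means among the compounds named here.

Three compounds share one core and differ only in the phenyl group carried on the five-membered ring. Compound 1 `COc1cc(/C=C/C(=O)c2cccc(-n3cc(-c4ccc(Cl)cc4)[nH]c3=O)c2)cc(OC)c1OC` gives 2460 nM in a functional assay on HCC 2998 cells (Homo sapiens) for inhibition; on this read-out higher numbers stand for weaker inhibition of growth and lower numbers for stronger inhibition of growth. Compound 2 `COc1cc(/C=C/C(=O)c2cccc(-n3cc(-c4ccccc4)[nH]c3=O)c2)cc(OC)c1OC` gives 1260 nM in this assay, and compound 3 `COc1ccc(-c2cn(-c3cccc(C(=O)/C=C/c4cc(OC)c(OC)c(OC)c4)c3)c(=O)[nH]2)cc1` gives 1640 nM. The three numbers lie close together: a 2.0-fold lower number from compound 1 to compound 2 (0.29 log units; within the scatter), a 1.5-fold lower number from compound 1 to compound 3 (0.18 log units; within the scatter), and a 1.3-fold higher number from compound 2 to compound 3 (0.11 log units; within the scatter). Compound 3 therefore stands among the other two without any separation that this assay can resolve.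

Compound 4 `COc1cc(/C=C/C(=O)c2cccc(-n3cc(-c4cc(OC)c(OC)c(OC)c4)[nH]c3=O)c2)cc(OC)c1OC` carries the change (3,4,5-trimethoxyphenyl in place of 4-methoxyphenyl on an aromatic carbon). The measured steps that bear on this position are the three just named; each exchanged a single group on that phenyl ring and none moved the number beyond the scatter. The step to compound 4 adds two further methoxy groups, which goes beyond any exchange measured so far, so the expectation rests on extrapolation from small, unresolved steps. Because compound 3 gives 1640 nM and no change on this ring has yet shifted the number beyond the scatter, compound 4 is expected near 1600 nM, within a range from 600 nM to 4500 nM. The expected step is a 1.0-fold lower number from compound 3 to compound 4 (0.01 log units; within the scatter), that is, nothing beyond the scatter.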

Compound 4, concentration for 50% growth inhibition: 1920 nM
Beside the measured number, compound 4's estimate is 1.2-fold (0.08 log units) below it, within the range that was stated.
By their numbers in this assay, from the lowest: compounds 2, 3, 4 and 1 (each within the scatter of the next).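

In this assay this position accepts a much larger change than the earlier exchanges of a single group, and even so the step remains small: the exchange of 4-methoxyphenyl for 3,4,5-trimethoxyphenyl gives a 1.2-fold higher number from compound 3 to compound 4 (0.07 log units; within the scatter) and stays unresolved. The same holds for the other two comparisons, with a 1.5-fold higher number from compound 2 to compound 4 (0.18 log units; within the scatter) against the unsubstituted phenyl and a 1.3-fold lower number from compound 1 to compound 4 (0.11 log units; within the scatter) against the 4-chlorophenyl, so all four groups on this aromatic carbon of the five-membered ring now read alike within the scatter, and the added methoxy groups and the extra hydrogen-bond acceptors bring no measurable separation here. No supporting measurement is available to account for this flat reading.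

Open, as far as these compounds go, is whether a group of a different kind on this phenyl ring, such as an amine or a carboxylic acid, or a longer chain in place of the phenyl, would move the number beyond the scatter in this assay at all. Also open, from the compounds shown here alone, is how the series responds to a change elsewhere on the shared core, since all four compounds keep the rest of it unchanged, including the second 3,4,5-trimethoxyphenyl group.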